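Bromo for trifluoromethyl on the anilide ring: cytotoxicity in macrophages

The source may report more compounds than this note shows. Statements on the series, on what has been measured and on what is new or still open speak of the compounds shown alone.

Measured compounds:
compound 1 `O=C(Nc1cc(C(F)(F)F)cc(C(F)(F)F)c1)c1cc(F)ccc1O` gives 2500 nM
compound 2 `O=C(Nc1ccc(C(F)(F)F)c(C(F)(F)F)c1)c1cc(Cl)ccc1O` gives 4900 nM
compound 3 `O=C(Nc1ccc(Br)c(C(F)(F)F)c1)c1cc(Cl)ccc1O` gives 4500 nM

These three were compared in an ADME assay on cells (Macrophage, Mus musculus) for cytotoxicity, read by resazurin assay, with a stated time of 3 days; a lower number here means a stronger inhibitor, a higher number a weaker inhibitor. Compound 1 and compound 2 differ in more than one place, and the difference between the two cores is not broken down here. Compound 2 and compound 3 differ in one place, (bromo in place of trifluoromethyl on an aromatic carbon), and that change gave a 1.1-fold lower number from compound 2 to compound 3 (0.04 log units; within the scatter).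

Compound 4 `O=C(Nc1cc(Br)cc(C(F)(F)F)c1)c1cc(F)ccc1O` has not yet been tested in this assay. It differs from compound 1 by bromo in place of trifluoromethyl on an aromatic carbon. This is the same kind of change as that from compound 2 to compound 3, but the surroundings differ: in compound 4 the bromo sits meta to a large group and meta to a trifluoromethyl group, whereas in compound 3 it sits ortho to a trifluoromethyl group and para to a large group.

Because the measured step of a 1.1-fold lower number from compound 2 to compound 3 (0.04 log units; within the scatter) stayed within the scatter, a similar outcome is expected for compound 4: an estimated step of a 1.1-fold lower number from compound 1 to compound 4 (0.04 log units; within the scatter). Compound 4 is therefore expected to give about 2300 nM, estimated to lie between 1100 nM and 4800 nM.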

Compound 4, half-maximal inhibitory concentration: 4700 nM
The estimate for compound 4 lay 2.0-fold (0.31 log units) below the measured number; the measured number falls inside the stated range.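

In this assay, bromo in place of trifluoromethyl on the core of compound 1 gave a 1.9-fold higher number from compound 1 to compound 4 (0.27 log units; within the scatter) and so stayed within the usual scatter. Set beside the earlier case, the two steps cannot be told apart: the same change on two cores in this assay, a 1.1-fold lower number (0.04 log units; within the scatter) from compound 2 to compound 3 and a 1.9-fold higher number (0.27 log units; within the scatter) from compound 1 to compound 4, 2.0-fold (0.31 log units) apart, within the scatter of two such steps. On these two cores the exchange therefore left the read-out within the scatter of the trifluoromethyl compound each time, and nothing here suggests that the core changes the outcome, but two pairs do not show that the same would hold on a further core or with the bromo at another place on the ring.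

The compounds shown leave open whether a group of a different kind at this place, such as a nitrile, an amine or a carboxylic acid, would also stay within the scatter. On these data alone, it also remains open whether a smaller halogen such as chloro in place of the trifluoromethyl would give a similar result on either core.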